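The compounds below may be only part of what the source reports. "The series", "measured", "known", "first", "only" and "open" are said of these compounds alone.

Compound 1 `CC(C)C[C@H](N)c1cc(C(F)(F)F)ccc1N1CCN(C(=O)COc2ccc3ccccc3c2)CC1`: 2000 nM
Compound 2 `CC(C)C[C@H](N)c1cc(C(F)(F)F)ccc1N1CCN(C(=O)C(C)Cc2ccc(Cl)c(Cl)c2)CC1`: 120 nM; 1600 nM (2 entries)
Compound 3 `CC(C)C[C@H](N)c1cc(C(F)(F)F)ccc1N1CCN(C(=O)CCC(N)=O)CC1`: > 10000 nM

All three share one core and differ only in the group attached to the carbonyl carbon of the amide. In an assay on HEK293 cells for displacement of a labelled ligand from Melanocortin receptor 4 (Homo sapiens) (on this read-out higher numbers stand for weaker inhibition and lower numbers for stronger inhibition), compound 1 gives 2000 nM. Compound 2 was measured more than once, with the several entries of compound 2 in this assay, 120 nM; 1600 nM (2 entries), and its two entries lie far apart. Compound 3 gives only a limit, > 10000 nM, so no single number is known for it (the limit of > 10000 nM in this assay, at which 1 of the 3 values shown sits). Among the measured compounds shown here, the one measured step that reaches compound 3 is an at least 5.0-fold higher number from compound 1 to compound 3 (0.69 log units; beyond the scatter): replacing the aromatic group with the small carbamoylmethyl group made inhibition weaker.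

Compound 4 `CC(C)C[C@H](N)c1cc(C(F)(F)F)ccc1N1CCN(C(=O)C(C)Cc2ccc(Cl)cc2)CC1` has not yet been measured. It differs from compound 3 by 1-(4-chlorobenzyl)ethyl in place of 2-carbamoylethyl on a carbonyl carbon. This change brings back an aromatic ring on that carbonyl carbon, as in compound 1 and compound 2, and compound 2 gives 120 nM; 1600 nM (2 entries). A step toward stronger inhibition, beyond the scatter, is therefore expected. Compound 4 is estimated at 700 nM, with a likely range from 150 nM to 4000 nM. This estimate corresponds to an expected step of an at least 14-fold lower number from compound 3 to compound 4 (1.15 log units; beyond the scatter).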

Compound 4, inhibition constant: 47 nM
For compound 4 the middle estimate is 15-fold (1.17 log units) above the measured one, and the stated range ends above it.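

In this assay, the change on this carbonyl carbon gives an at least 210-fold lower number from compound 3 to compound 4 (2.32 log units; beyond the scatter), which shows that the group here can shift inhibition strongly in the stronger direction, and not only weaken it as the earlier step did. Compound 3 stands at a limit and not at a number: the limit of > 10000 nM in this assay, at which 1 of the 4 values shown sits. Compound 4 also carries an aromatic ring, as compound 1 does, yet 1-(4-chlorobenzyl)ethyl gives a 43-fold lower number from compound 1 to compound 4 (1.63 log units; beyond the scatter), so among these two compounds an aromatic ring alone does not settle the result and the kind of group bearing it matters.

The step between compound 2 and compound 4, which differ only in the chlorine pattern on the ring, cannot be read because the entries of compound 2 lie far apart: the several entries of compound 2 in this assay, 120 nM; 1600 nM (2 entries). The compounds shown also leave open which part of 1-(4-chlorobenzyl)ethyl carries the gain, and where a plain benzyl group without chlorine, or a chain ending in an amine or a carboxylic acid, would fall on this read-out.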